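This account rests on a few compounds, and the source may have more. Where it says the series, first, only, none or still open, it means among the compounds named here.

Measured in a functional assay on A549 cells (Homo sapiens) for antiproliferative activity, read by MTT assay, with a stated time of 48 h; a lower number here means a stronger inhibitor, a higher number a weaker inhibitor
- compound 1 `Clc1ccc2[nH]c(-c3cn(-c4ccccc4)nc3-c3ccccc3)nc2c1` gives 2370 nM
- compound 2 `Cc1ccc2[nH]c(-c3cn(-c4ccccc4)nc3-c3ccccc3)nc2c1` gives 3610 nM

Not yet measured: compound 3 `FC(F)(F)c1ccc2[nH]c(-c3cn(-c4ccccc4)nc3-c3ccccc3)nc2c1`

Compound 2 at 3610 nM and compound 1 at 2370 nM lie within the scatter of each other, so neither ranks ahead. The next change is trifluoromethyl in place of methyl on an aromatic carbon and it falls on the carbon that carries chloro in compound 1. For the measured compounds named here, only one measured step bears on this carbon: a 1.5-fold higher number from compound 1 to compound 2 (0.18 log units; within the scatter) and it does not go beyond the scatter. Going by the values given here, the data hold no trifluoromethyl example, so the range stays wide. No step beyond the scatter is expected in this assay for this change. The expected step is a 1.3-fold lower number from compound 2 to compound 3 (0.11 log units; within the scatter) and this estimate stays within the scatter. For compound 3 the estimated value is 2800 nM with an expected range from 1200 nM to 6500 nM as the working figure.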

Compound 3, half-maximal inhibitory concentration: 5930 nM
The estimate for compound 3 lay 2.1-fold (0.33 log units) below the measured number; the range from low to high includes it.
By their numbers in this assay, from the lowest: compounds 1, 2 and 3 (each within the scatter of the next, the first and the last beyond it).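

In this assay, replacing methyl with trifluoromethyl on this aromatic carbon gives a 1.6-fold higher number from compound 2 to compound 3 (0.22 log units; within the scatter) and so does not separate the two compounds. The position does now show its first step beyond the scatter, a 2.5-fold higher number from compound 1 to compound 3 (0.40 log units; beyond the scatter) with trifluoromethyl in place of chloro, so the group on this carbon can shift the number, though only modestly across the three groups shown. No measured evidence here accounts for that difference.

Going by these compounds, whether a group of another kind on this carbon, such as an amine, a carboxylic acid or a methoxy group, would move the number further remains open. On these data alone, it is also open whether the gap between chloro and trifluoromethyl would hold with a different group on the two phenyl rings of the shared core.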